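A Single Changed Stereocentre in Compound 3

A few compounds are considered here, and "the series" means these few. Any claim that something is new, unique, unknown or untested is made for them only; others in the source may bear on it.

Compound 1 `COC1=C(Br)[C@H](O)[C@@]2(C=C1Br)CC(C(=O)NCCCCCNC(=O)C1=NO[C@]3(C=C(Br)C(=O)[C@@H]4O[C@@H]43)C1)=NO2` and compound 2 `COC1=C(Br)[C@H](O)[C@@]2(C=C1Br)CC(C(=O)NCCCCNC(=O)C1=NO[C@]3(C=C(Br)C(=O)[C@@H](Br)[C@@H]3O)C1)=NO2` have both been tested in a functional assay on MDA-MB-231 cells (Homo sapiens) for cytotoxicity, read by sulforhodamine B assay; on this read-out lower numbers stand for higher toxicity in this test and higher numbers for lower toxicity in this test. In this assay compound 1 gives 6400 nM and compound 2 gives 7600 nM, two values that lie within the usual scatter of each other. Compound 3 `COC1=C(Br)[C@H](O)[C@@]2(C=C1Br)CC(C(=O)NCCCCNC(=O)C1=NO[C@]3(C=C(Br)C(=O)[C@H](Br)[C@@H]3O)C1)=NO2` is still unmeasured. Set against compound 2, it shows this difference: the two compounds have the same atoms and bonds and differ only in configuration as drawn: 1 of 5 stereo elements differ; a stereocentre at a saturated ring carbon is drawn S in compound 2 and R in compound 3. Among the measured compounds shown here, no measured pair here reveals what such a change does, so no step beyond the scatter is expected in this assay, in either direction. For compound 3 the expected value is 7000 nM, with an estimated range from 3000 nM to 16000 nM.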

Compound 3, concentration lethal to 50% of the cells: 8000 nM
The estimate for compound 3 lay 1.1-fold (0.06 log units) below the measured number; low and high end bracket the measured number.
By their numbers in this assay, from the lowest: compounds 1, 2 and 3 (each within the scatter of the next).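

The comparison is a clean one: the fact that compounds 2 and 3 differ only in the configuration as drawn. Across this pair, this assay gives a 1.1-fold higher number from compound 2 to compound 3 (0.02 log units; within the scatter). The earlier compounds shown here offered no such pair; here, drawing this stereocentre at a saturated ring carbon as S or as R moves the number by no more than the scatter.

As far as these compounds go, whether the other stereo elements are equally free to change remains open, since each of them is drawn the same in compound 2 and compound 3. Also open, from the compounds shown here alone, is how an amine or a carboxylic acid on the shared core would behave.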